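The compounds below may be only part of what the source reports. "The series", "measured", "known", "first", "only" and "open" are said of these compounds alone.

Values in a functional assay on MCF7 cells (Homo sapiens) for inhibition, read by sulforhodamine B assay, with a stated time of 48 h (on this read-out higher numbers stand for weaker inhibition of growth and lower numbers for stronger inhibition of growth), for the three measured compounds:
Compound 1 `c1cc2c(cc1NC1=NCCO1)CCC2` gives 9100 nM
Compound 2 `c1cc(OC2CCCC2)ccc1NC1=NCCO1` gives 23100 nM
Compound 3 `c1cc(NC2=NCCO2)cc(OC2CCCC2)c1` gives 62100 nM

Compound 3 stands highest of the three, and its gaps to compound 2 and to compound 1 both lie beyond the scatter, which makes it the weakest growth inhibitor measured so far. Compound 4 `c1ccc(Oc2cccc(NC3=NCCO3)c2)cc1` keeps the core of compound 3 but has phenyl in place of cyclopentyl on an oxygen on an aromatic ring. Among the measured compounds shown here, no measured compound carries phenyl there, so the data offer no direct guide to this change. Both groups are carbon rings with no hydrogen-bond donors or acceptors, and no step beyond the scatter is expected in this assay, though a small drift to a lower number seems more likely than a rise, given that compound 3 sits at the top of the series (62100 nM). The estimated change is modest (a 1.8-fold lower number from compound 3 to compound 4 (0.25 log units; within the scatter)). For compound 4 the expected value is 35000 nM within an estimated range of 12000 nM to 90000 nM.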

Compound 4, concentration for 50% growth inhibition: 12200 nM
The estimate for compound 4 lay 2.9-fold (0.46 log units) above the measured number; low and high end bracket the measured number.
By their numbers in this assay, from the lowest: compounds 1, 4 and 2 (each within the scatter of the next, the first and the last beyond it); then compound 3.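

In this assay, among the compounds shown here, phenyl in place of cyclopentyl on an oxygen on an aromatic ring gives a 5.1-fold lower number from compound 3 to compound 4 (0.71 log units; beyond the scatter), the first step at this place that can be read. The result shows that this place is sensitive to the choice of carbon ring: a five-membered non-aromatic ring and a six-membered aromatic ring, neither with hydrogen-bond donors or acceptors and neither with a net charge, are separated by a step beyond the scatter. Nothing available accounts for this step, so it stands as an observation only.

The compounds shown leave open whether the step follows from aromaticity or from ring size, a question that a cyclohexyl group on the same oxygen would address. They also leave open how a benzyl group or a phenyl ring bearing a methoxy group would read at this place.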